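This account rests on a few compounds, and the source may have more. Where it says the series, first, only, none or still open, it means among the compounds named here.

Measured so far:

Compound 1, `CCOC(=O)c1cnn(-c2nc(-c3ccc(OC)cc3)c(C#N)c(=O)n2C)c1N`, gives 79 ug/mL in a functional assay, with a stated time of 150 min; a lower number here means a stronger inhibitor, a higher number a weaker inhibitor.
Compound 2, `CCOC(=O)c1cnn(-c2nc(-c3ccc(N(C)C)cc3)c(C#N)c(=O)n2C)c1N`, gives 115 ug/mL in this assay.
Compound 3, `Cn1c(NN)nc(-c2ccccc2O)c(C#N)c1=O`, gives 46 ug/mL in this assay.

Compound 2 stands highest of the three numbers. Its nearest neighbour is compound 1, whose value sits within the scatter of it, so the two cannot be ordered; compound 3 lies furthest away, with a gap beyond the scatter. Compound 4, `CCOC(=O)c1cnn(-c2nc(-c3ccccc3Cl)c(C#N)c(=O)n2C)c1N`, has not yet been measured. It differs from compound 2 in one place: 2-chlorophenyl in place of 4-(dimethylamino)phenyl on an aromatic carbon. Among the compounds with values here, only one measured step exists for comparison, a 1.5-fold higher number from compound 1 to compound 2 (0.16 log units; within the scatter), and that step swapped one substituent on the same aromatic carbon for another without moving the number beyond the scatter. Within the data shown here, no measured step involves a chlorine or an unsubstituted phenyl, so the change to compound 4 rests on thin ground. The expectation is therefore a step of about a 1.3-fold lower number from compound 2 to compound 4 (0.11 log units; within the scatter), that is, nothing clearly beyond the scatter in either direction. Compound 4 is estimated at 90 ug/mL, with a range from 40 ug/mL to 200 ug/mL.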

Compound 4, half-maximal inhibitory concentration: 93 ug/mL
Compound 4: the middle estimate sits 1.0-fold (0.01 log units) below what was measured, and the stated range covers the measured number.
By their numbers in this assay, from the lowest: compounds 3, 1, 4 and 2 (each within the scatter of the next, the first and the last beyond it).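

In this assay, 2-chlorophenyl in place of 4-(dimethylamino)phenyl gives a 1.2-fold lower number from compound 2 to compound 4 (0.09 log units; within the scatter), and in place of 4-methoxyphenyl it gives a 1.2-fold higher number from compound 1 to compound 4 (0.07 log units; within the scatter). This aromatic carbon has now carried three different substituted phenyl groups, including one with chlorine and no hydrogen-bond acceptor, without any step going beyond the scatter, so the three compounds cannot be ordered. Nothing available explains why these numbers stay so close.

The compounds shown leave open whether a group without a phenyl ring on this carbon, such as cyclohexyl or morpholine, would give a clearly different number. They also leave open whether an unsubstituted phenyl, or a phenyl bearing a carboxylic acid, would move the number beyond the scatter.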